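From compound 3 to compound 4: methoxy for propyl

A few compounds are considered here, and "the series" means these few. Any claim that something is new, unique, unknown or untested is made for them only; others in the source may bear on it.

In a functional assay on MGC-803 cells (Homo sapiens) for inhibition, read by MTT assay, with a stated time of 48 h (on this read-out lower numbers stand for stronger inhibition and higher numbers for weaker inhibition), compound 1 `COc1cc(NCc2ccccc2)cc(OC)c1OC` gives > 80000 nM, which is a limit of the assay and not a number. Compound 2 `COc1ccc(CNc2cc(OC)c(OC)c(OC)c2)cc1[N+](=O)[O-]` gives 19400 nM. Compound 3 `CCCCC(=O)N(Cc1ccc(OC)c(O)c1)c1cc(OC)c(OC)c(OC)c1` gives 66 nM, the lowest number in the set, and the gap to compound 2 lies beyond the scatter. Compound 4 `COCC(=O)N(Cc1ccc(OC)c(O)c1)c1cc(OC)c(OC)c(OC)c1` has methoxy in place of propyl on a saturated chain carbon bound to a carbonyl carbon. Within the data shown here, no measured step covers this change, so the expectation rests on the structural change alone. In this assay a modest step toward weaker inhibition is expected, estimated as a 3.0-fold higher number from compound 3 to compound 4 (0.48 log units; beyond the scatter). For compound 4 the estimated value is 200 nM, with an expected range of 50 nM to 900 nM.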

Compound 4, half-maximal inhibitory concentration: 79 nM
The estimate for compound 4 lay 2.5-fold (0.40 log units) above the measured number; measured number inside the range.
By their numbers in this assay, from the lowest: compounds 3 and 4 (each within the scatter of the next); then compound 2. At a limit, above all of these: compound 1.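

Methoxy in place of propyl on a saturated chain carbon bound to a carbonyl carbon gives a 1.2-fold higher number from compound 3 to compound 4 (0.08 log units; within the scatter) in this assay. Among these compounds, this is the first reading at this position, since compound 1 and compound 2 carry no carbonyl, and here butyl and methoxymethyl read alike. Nothing measured here bears on why the two groups read alike.

On these data alone, whether an amine, a carboxylic acid or a longer chain at this place would read the same stays open. As far as these compounds go, what the carbonyl itself contributes also stays open, as compound 3 differs from compound 2 in more than one place.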